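The compounds below may be only part of what the source reports. "The series", "measured", "known", "first", "only" and "open" are said of these compounds alone.

Compound 1 `Fc1cccc(F)c1Cn1c(-c2c(F)cccc2F)nc2ccncc21`: 99000 nM
Compound 2 `Cc1cccc(Cn2ccc3nc(-c4ccccc4)nc-3c2)c1`: > 100000 nM

In an ADME assay on MDBK cells (Bos taurus) for cytotoxicity (a higher number here means that more compound is tolerated, a lower number that less compound is tolerated), compound 1 gives 99000 nM. For compound 2 the assay reports only a limit, > 100000 nM, not a number. That is the limit of > 100000 nM in this assay, at which 1 of the 2 values shown sits, so compound 2 stands at the upper edge of what this assay can report. Compound 3 `Fc1cccc(Cn2ccc3nc(-c4ccccc4)nc-3c2)c1` has not yet been measured. It differs from compound 2 by fluoro in place of methyl on an aromatic carbon. Within the data shown here, no measured step guides this change, so the expected step is none beyond the usual scatter. Compound 3 is therefore expected at 100000 nM, within 50000 nM to 200000 nM. The step of a number no higher from compound 2 to compound 3 (the limit leaves the size open) is thus expected to be flat, likely ending again at the limit.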

Compound 3, half-maximal cytotoxic concentration: > 100000 nM
Compound 3 ended at the assay's limit (the forecaster's own chance of this, stated with the estimate: 70%); the middle value sits exactly at the limit.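

No step can be read between compound 2 and compound 3, because each gives only a limit rather than a number: the limit of > 100000 nM in this assay, at which 2 of the 3 values shown sit. On these data alone, whether fluoro in place of methyl changes anything in this assay stays open.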